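The source may report more compounds than this note shows. Statements on the series, on what has been measured and on what is new or still open speak of the compounds shown alone.

Measured compounds:

compound 1, `N#CC1(c2cc(CCO)cc(-c3ccnc4[nH]nc(C(F)(F)F)c34)c2)CC1`, gives 25 nM in an assay on isolated protein for inhibition of protein kinase C epsilon type (Homo sapiens), read by coupled enzyme assay; a higher number here means a weaker inhibitor, a lower number a stronger inhibitor.
compound 2, `C[C@@H](O)Cc1cc(-c2ccnc3[nH]nc(C(F)(F)F)c23)cc(C2(C#N)CC2)c1`, gives 34 nM in this assay.

Among these two numbers compound 2 stands highest, with compound 1 nearest at a lower number, and the step from compound 1 to compound 2 is a 1.4-fold higher number from compound 1 to compound 2 (0.13 log units; within the scatter), so the two compounds cannot be told apart in potency. Going by the values given here, that step consisted of a methyl in place of hydrogen on a saturated chain carbon bound to an oxygen on a saturated carbon and a saturated chain carbon, and it created the one stereocentre in compound 2.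

Compound 3, `C[C@H](O)Cc1cc(-c2ccnc3[nH]nc(C(F)(F)F)c23)cc(C2(C#N)CC2)c1`, keeps every atom and bond of compound 2 but turns that centre round: the two compounds have the same atoms and bonds and differ only in configuration as drawn: 1 of 1 stereo elements differ; a stereocentre at a saturated chain carbon is drawn R in compound 2 and S in compound 3. Among the compounds with values here, no measured step here involves a change of configuration, so the only guidance is that the achiral compound 1 and the one drawn enantiomer sit within the scatter of each other, which suggests the methyl is not doing much in either orientation. In this assay compound 3 is therefore expected to land close to compound 2, with the step of a 1.0-fold higher number from compound 2 to compound 3 (0.01 log units; within the scatter) as the estimate and no direction favoured. The estimated value for compound 3 is 35 nM, within a range from 12 nM to 110 nM.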

Compound 3, inhibition constant: 51 nM
Compound 3: the middle estimate sits 1.5-fold (0.16 log units) below what was measured; the measured number falls inside the stated range.
By their numbers in this assay, from the lowest: compounds 1, 2 and 3 (each within the scatter of the next, the first and the last beyond it).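

In this assay, turning the stereocentre round gives a 1.5-fold higher number from compound 2 to compound 3 (0.18 log units; within the scatter), so this measurement cannot separate the two orientations of the methyl in potency. The comparison is a clean test of orientation alone, because nothing else changes between the two structures: the fact that compounds 2 and 3 differ only in the configuration as drawn

The new compound also adds a second reading of the methyl in place of hydrogen on the chain carbon that bears the oxygen: the S form gives a 2.0-fold higher number from compound 1 to compound 3 (0.31 log units; beyond the scatter), a modest step that clears the scatter, whereas the R form in compound 2 stayed within the scatter of compound 1, yet compound 2 and compound 3 remain within the scatter of each other, so any preference at this carbon is slight at best.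

Going by these compounds, all three compounds keep the hydroxyl on the chain, so the effect of an amine or a methoxy group at that carbon remains open, as does that of an ethyl group in place of the methyl. On these data alone, whether a longer chain, or a replacement for the nitrile elsewhere on the molecule, would move the number further also remains open.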